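The source may report more compounds than this note shows. Statements on the series, on what has been measured and on what is new or still open speak of the compounds shown alone.

Compound 1 `CC(C)(C)c1ccc(C(=O)NN2C(=O)NC3(CC3(C)C)C2=O)cc1` is the most potent of the three compounds measured in a functional assay on the whole organism (Hindlimb) for inhibition, with Mus musculus as the target, with a stated time of 0.5 h; a lower number here means that less compound is needed, a higher number that more compound is needed for the effect: compound 1 gives 30 mg/kg. Its nearest neighbour on this scale is compound 3 `CC1(C)CC12NC(=O)N(NC(=O)c1ccccc1F)C2=O`, which in this assay gives 100 mg/kg, and the furthest is compound 2 `CC1(C)CC12NC(=O)N(NC(=O)c1ccccc1Cl)C2=O`, which gives 300 mg/kg. Within the data shown here, the only step between measured compounds concerns those two: a 3.0-fold lower number from compound 2 to compound 3 (0.48 log units; beyond the scatter).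

Compound 4 `COc1ccc(C(=O)NN2C(=O)NC3(CC3(C)C)C2=O)cc1` is the compound not yet measured. It differs from compound 1 in one place: methoxy in place of tert-butyl on an aromatic carbon. The change sits on an aromatic carbon of a six-membered aromatic ring of carbon only, para to a large group.

Among the measured compounds shown here, no measured pair in this set carries the same change. For the measured compounds named here, the single step on record, from compound 2 to compound 3, swaps one halogen for another and sits elsewhere on the structure, so it gives no direct guide to what the methoxy in place of tert-butyl will do. The expectation for compound 4 therefore rests mainly on compound 1 itself, with a wide margin in either direction, and no step beyond the scatter can be predicted with confidence: the estimate for compound 4 is a 2.0-fold higher number from compound 1 to compound 4 (0.30 log units; within the scatter). On that basis compound 4 is expected to give 60 mg/kg in this assay, with a plausible range from 20 mg/kg to 200 mg/kg.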

Compound 4, minimum effective dose: 100 mg/kg
Beside the measured number, compound 4's estimate is 1.7-fold (0.22 log units) below it; low and high end bracket the measured number.
By their numbers in this assay, from the lowest: compound 1; then compounds 3 and 4 (each within the scatter of the next); then compound 2.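

In this assay, a 3.3-fold higher number from compound 1 to compound 4 (0.52 log units; beyond the scatter), so with the rest of compound 1 held fixed, the group on this aromatic carbon, para to a large group, does affect the dose needed, and methoxy in place of tert-butyl is a modest loss rather than a neutral swap. Among these compounds, this is the first measured change at this position, as the only earlier step, a 3.0-fold lower number from compound 2 to compound 3 (0.48 log units; beyond the scatter), swapped one halogen for another elsewhere on the structure. The change removes tert-butyl and brings in methoxy, which differ in both heavy atoms and hydrogen-bond acceptors, and no measurement here separates these differences or explains the higher number.

Going by these compounds, whether an amine, a carboxylic acid or a longer alkyl chain on this aromatic carbon would give a number closer to that of compound 1 or to that of compound 4 remains open. The compounds shown also leave open whether tert-butyl would keep its advantage over methoxy elsewhere on the ring, or on a core other than that of compound 1.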